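Para-substituent swap on the aryl ring: chloro to methyl

The source may hold more compounds than are shown below. What is called first, only, known or untested is meant among the compounds shown, and "the series" means these compounds.

Measured so far:
compound 1 `O=C(O)CCC(=O)/C=C/c1cn(-c2ccccc2)nc1-c1ccccc1` — 27.9%
compound 2 `O=C(O)CCC(=O)/C=C/c1cn(-c2ccccc2)nc1-c1ccc(Cl)cc1` — 3.43%

In a functional assay on the whole organism (strain albino) for inhibition, with Rattus norvegicus as the target, read by paw edema, with stated times of 30 min and 1 h, at a dose of 50 mg/kg by the oral route (a higher number here means more inhibition at the dose given (going by the name of the read-out), a lower number less inhibition), compound 2 gives 3.43%, the lowest of the two numbers; the step of a number 24.5 percentage points lower from compound 1 to compound 2 (beyond the scatter) is beyond the scatter. Compound 3 `Cc1ccc(-c2nn(-c3ccccc3)cc2/C=C/C(=O)CCC(=O)O)cc1` differs from compound 2 by methyl in place of chloro on an aromatic carbon. Among the measured compounds shown here, no measured step covers a methyl in place of chloro, so the only guide is that chloro in place of hydrogen lowered inhibition; the methyl may recover part of that, but the direction is uncertain. Compound 3 is expected to give 15% (range 0% to 35%), an estimated step of a number 11.6 percentage points higher from compound 2 to compound 3 (beyond the scatter).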

Compound 3, a percentage reported as inhibition, in the whole organism at one dose (the size of the read-out at that dose, not a potency): 4.41%
For compound 3 the middle estimate is 10.6 percentage points above the measured one, within the range that was stated.
By their numbers in this assay, from the lowest: compounds 2 and 3 (each within the scatter of the next); then compound 1.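

In this assay the change from 4-chlorophenyl to 4-methylphenyl gives a number 1 percentage points higher from compound 2 to compound 3 (within the scatter) and so does not separate the two groups. Methyl in place of hydrogen gives a number 23.5 percentage points lower from compound 1 to compound 3 (beyond the scatter) and this shows that the loss seen with chloro also occurs with a carbon substituent at this position. Nothing measured here accounts for this loss. From the compounds shown here alone, whether an amine or a methoxy group on this carbon would show the same loss remains open. Also open, going by these compounds, is whether a substituent at any other place on this ring would do so.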